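From isobutoxy to 2-methoxyethoxy on compound 2

The source may report more compounds than this note shows. Statements on the series, on what has been measured and on what is new or still open speak of the compounds shown alone.

In an ADME assay on Caco-2 cells (Homo sapiens) for permeability, in the apical to basolateral direction, tested at 25 uM (on this read-out higher numbers stand for higher permeability and lower numbers for lower permeability), compound 1 (`CCCCOc1ncc(S(=O)(=O)N2CCN(CC)CC2)cc1-c1nc2c(CC)n(C3CN(C)C3)nc2c(=O)[nH]1`) gives 6 10^-6 cm/s while compound 2 (`CCc1c2nc(-c3cc(S(=O)(=O)N4CCN(CC)CC4)cnc3OCC(C)C)[nH]c(=O)c2nn1CCOC`) reaches 40 10^-6 cm/s and stands highest of the two, beyond the scatter. Compound 3 (`CCc1c2nc(-c3cc(S(=O)(=O)N4CCN(CC)CC4)cnc3OCCOC)[nH]c(=O)c2nn1CCOC`) differs from compound 2 in one place (methoxymethyl in place of isopropyl on a saturated chain carbon bound to an oxygen on an aromatic ring), with methoxymethyl in place of isopropyl on a saturated chain carbon bound to an oxygen on an aromatic ring. Among the compounds with values here, no measured step covers this change, so the expectation is only tentative. A modest downward step is expected in this assay and is estimated as a 1.8-fold lower number from compound 2 to compound 3 (0.26 log units; within the scatter) from this single change. For compound 3 the estimated value is 22 10^-6 cm/s within a range of 9 10^-6 cm/s to 45 10^-6 cm/s as expected here.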

Compound 3, apparent permeability in the Caco-2 assay: 9 10^-6 cm/s
Estimate against measurement, compound 3: 2.4-fold (0.39 log units) above; low and high end bracket the measured number.
By their numbers in the Caco-2 assay, from the lowest: compounds 1 and 3 (each within the scatter of the next); then compound 2.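

On a saturated chain carbon bound to an oxygen on an aromatic ring, methoxymethyl in place of isopropyl has a clear effect in the Caco-2 assay, with a 4.4-fold lower number from compound 2 to compound 3 (0.65 log units; beyond the scatter). This is the first single-place change read in the series, so the position is now shown to matter for this read-out. In a physicochemical assay for lipophilicity, at pH 7.4 (on this read-out higher numbers stand for higher lipophilicity and lower numbers for lower lipophilicity), compound 2 gives 2.9 and compound 3 gives 1.4. The same change lowers lipophilicity, which may lie behind the drop: the measured distribution coefficient of compound 2, 2.9, and of compound 3, 1.4, a number 1.50 log units lower (beyond the scatter)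

This single pair cannot show whether the link holds for other groups at this place. A longer chain or an amine there remains an open case, as does the same change on a different group at the other side of the shared core.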